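The source may hold more compounds than are shown below. What is called first, only, known or untested is meant among the compounds shown, and "the series" means these compounds.

In an assay on isolated protein for inhibition of ubiquitin carboxyl-terminal hydrolase 7 (Homo sapiens), with stated times of 30 min and 2 h (a lower number here means a stronger inhibitor, a higher number a weaker inhibitor), three compounds have been measured:

compound 1 `Cn1nc2c(=O)n(CC3(O)CCN(Cc4ccc(-c5ccncc5)cc4Cl)CC3)cnc2c1-c1ccc(CN)cc1`: 257 nM
compound 2 `Cn1cc(-c2ccc(CN3CCC(O)(Cn4cnc5c(-c6ccc(CN)cc6)n(C)nc5c4=O)CC3)c(Cl)c2)cn1`: 291 nM
compound 3 `Cn1nc2c(=O)n(CC3(O)CCN(Cc4ccc(C5=CCCC5)cc4Cl)CC3)cnc2c1-c1ccc(CN)cc1`: 76.9 nM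

Compound 3 has the lowest number of the three, and its steps to both others lie beyond the scatter. Compound 4 `Cn1nc2c(=O)n(CC3(O)CCN(Cc4ccc(-c5ccoc5)cc4Cl)CC3)cnc2c1-c1ccc(CN)cc1` differs from compound 3 in one place: furan-3-yl in place of cyclopent-1-en-1-yl on an aromatic carbon. The measured steps that bear on this are a 3.3-fold lower number from compound 1 to compound 3 (0.52 log units; beyond the scatter) and a 3.8-fold lower number from compound 2 to compound 3 (0.58 log units; beyond the scatter), in which cyclopent-1-en-1-yl replaced pyridin-4-yl or 1-methyl-1H-pyrazol-4-yl and the number fell modestly. Moving from cyclopent-1-en-1-yl back to a ring of another kind, furan-3-yl, is therefore expected to give a modest rise in this assay, a 2.1-fold higher number from compound 3 to compound 4 (0.32 log units; beyond the scatter). Compound 4 is estimated at 160 nM, with a range from 60 nM to 420 nM.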

Compound 4, half-maximal inhibitory concentration: 177 nM
The estimate for compound 4 lay 1.1-fold (0.04 log units) below the measured number, and the stated range covers the measured number.
By their numbers in this assay, from the lowest: compound 3; then compounds 4, 1 and 2 (each within the scatter of the next).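

Going to furan-3-yl, with the same count of heavy atoms, gives a 2.3-fold higher number from compound 3 to compound 4 (0.36 log units; beyond the scatter) in this assay, so a five-membered ring alone does not keep the number low. Going by these compounds alone, the other aromatic rings stay within the scatter, with a 1.5-fold lower number from compound 1 to compound 4 (0.16 log units; within the scatter) and a 1.6-fold lower number from compound 2 to compound 4 (0.22 log units; within the scatter), leaving cyclopent-1-en-1-yl the only group here set apart. No supporting data explain this step.

Still open, from the compounds shown here alone, is whether the lower number goes with the non-aromatic ring or with a ring of carbon only. A phenyl or a saturated cyclopentyl group at this position would help separate the two.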